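The source may report more compounds than this note shows. Statements on the series, on what has been measured and on what is new or still open speak of the compounds shown alone.

Of the compounds shown here, three sharing one core have been measured in an ADME assay on the whole organism (Rattus norvegicus, strain Sprague-Dawley) for pharmacokinetics, read by LC-MS; a higher number here means that more of the compound sits outside the plasma, a lower number that more of the compound stays in the plasma: compound 1 (`N#Cc1ccc(S(=O)(=O)[C@H]2CN(S(=O)(=O)c3ccc(Cl)cc3Cl)C[C@@]2(O)CO)cc1`) gives 2.3 L/kg, compound 2 (`N#Cc1ccc(S(=O)(=O)[C@H]2CN(S(=O)(=O)c3ccc(Cl)cc3C#N)C[C@@]2(O)CO)cc1`) gives 2.6 L/kg and compound 3 (`N#Cc1ccc(S(=O)(=O)[C@H]2CN(S(=O)(=O)c3ccc(C#N)cc3Cl)C[C@@]2(O)CO)cc1`) gives 2.2 L/kg. All three lie within the scatter of each other, so compound 3 stands level with the other two. Compound 4 (`N#Cc1ccc(S(=O)(=O)N2C[C@H](S(=O)(=O)c3ccc(Cl)cc3)[C@](O)(CO)C2)c(Cl)c1`) differs from compound 3 by chloro in place of cyano on an aromatic carbon, 4-cyanophenyl to 4-chlorophenyl. The closest evidence is the reverse swap, cyano in place of chloro, made at other places in the molecule: a 1.1-fold higher number from compound 1 to compound 2 (0.05 log units; within the scatter) and a 1.0-fold lower number from compound 1 to compound 3 (0.02 log units; within the scatter). Both steps were small, and neither tests this exact place, so no step beyond the scatter is expected in this assay. The estimated step is a 1.1-fold higher number from compound 3 to compound 4 (0.04 log units; within the scatter). For compound 4 the estimate is 2.4 L/kg, with an expected range of 1.4 L/kg to 4 L/kg.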

Compound 4, volume of distribution at steady state: 4.5 L/kg
Estimate against measurement, compound 4: 1.9-fold (0.27 log units) below; measured number above the stated range.
By their numbers in this assay, from the lowest: compounds 3, 1, 2 and 4 (each within the scatter of the next, the first and the last beyond it).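

Putting chloro in place of cyano on the 4-cyanophenyl group gives a step that passes the scatter in this assay (a 2.0-fold higher number from compound 3 to compound 4 (0.31 log units; beyond the scatter)), whereas the earlier swaps on the other aromatic ring stayed within it. This position may therefore respond more strongly to the change, but the comparison between the two places does not settle that: the same change on two cores in this assay, a 1.1-fold higher number (0.05 log units; within the scatter) from compound 1 to compound 2 and a 2.0-fold lower number (0.31 log units; beyond the scatter) from compound 4 to compound 3, 2.3-fold (0.36 log units) apart, within the scatter of two such steps.

From the compounds shown here alone, what a carboxylic acid, an amine or a methoxy group would do at this position remains open. So does whether the step would recur on another core.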